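A smaller halogen pattern and its expected clearance

The source may report more compounds than this note shows. Statements on the series, on what has been measured and on what is new or still open speak of the compounds shown alone.

Three compounds sharing one core have been run in an ADME assay on microsomes from liver (Mus musculus) for metabolic stability; on this read-out lower numbers stand for slow clearance and higher numbers for fast clearance. Compound 1 `CNc1[nH]c(=O)n(O)c(=O)c1C(=O)NCc1ccccc1` gives 51 uL/min, compound 2 `CCNc1[nH]c(=O)n(O)c(=O)c1C(=O)NCc1ccccc1` gives 355 uL/min, and compound 3 `CCNc1[nH]c(=O)n(O)c(=O)c1C(=O)NCc1cccc(Cl)c1F` gives 850 uL/min, the highest of the three. The measured steps were a 7.0-fold higher number from compound 1 to compound 2 (0.84 log units; beyond the scatter) and a 2.4-fold higher number from compound 2 to compound 3 (0.38 log units; beyond the scatter). Compound 4 `CCNc1[nH]c(=O)n(O)c(=O)c1C(=O)NCc1ccc(F)cc1` has not yet been measured; it differs from compound 3 by 4-fluorophenyl in place of 3-chloro-2-fluorophenyl on a saturated chain carbon bound to an amide-type nitrogen. Among the measured compounds shown here, only the step from compound 2 to compound 3 bears on this change, and compound 4 partly reverses it, so a modest fall in this assay is expected, back toward the number of compound 2. The expected step is a 1.9-fold lower number from compound 3 to compound 4 (0.28 log units; within the scatter). Compound 4 is therefore estimated at 450 uL/min, with a range from 200 uL/min to 1000 uL/min.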

Compound 4, intrinsic clearance in a liver preparation (reported as CLH), per the amount of preparation that the assay uses: 336 uL/min
The estimate for compound 4 lay 1.3-fold (0.13 log units) above the measured number, and the stated range covers the measured number.
By their numbers in this assay, from the lowest: compound 1; then compounds 4 and 2 (each within the scatter of the next); then compound 3.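

In this assay, replacing 3-chloro-2-fluorophenyl with 4-fluorophenyl gives a 2.5-fold lower number from compound 3 to compound 4 (0.40 log units; beyond the scatter), and adding the fluoro to the phenyl gives a 1.1-fold lower number from compound 2 to compound 4 (0.02 log units; within the scatter), which lies within the scatter. At this position, then, a fluoro alone does not separate compound 4 from compound 2, while the higher number stays with the 3-chloro-2-fluorophenyl of compound 3. Nothing measured here explains this difference. The compounds shown leave open whether 3-chlorophenyl or 2-fluorophenyl alone would match compound 3 or stay with compound 2.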